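The source may hold more compounds than are shown below. What is called first, only, known or untested is meant among the compounds shown, and "the series" means these compounds.

The series shares one core, seen in compound 1 `CC(C)NC(=O)/C=C1\CCc2ccc(F)cc21`, where the amide nitrogen carries an isopropyl group. In a functional assay on the whole organism with Mus musculus as the target, in the rotarod test (a lower number here means that less compound is needed, a higher number that more compound is needed for the effect), compound 1 gives only a limit, > 100 mg/kg, and no number behind it. Compound 2 `NC(=O)/C=C1\CCc2cc(F)cc(F)c21` and compound 3 `NC(=O)/C=C1\CCc2cc(F)c(F)cc21` are primary amides with a differently fluorinated core; in this assay compound 2 gives 81 mg/kg and compound 3 gives 82 mg/kg. Among the compounds with values here, the only evidence on compound 1 is the limit of > 100 mg/kg in this assay, at which 1 of the 3 values shown sits. Compound 4 `CCNC(=O)/C=C1\CCc2ccc(F)cc21` differs from compound 1 by hydrogen in place of methyl on a saturated chain carbon bound to an amide-type nitrogen and a saturated chain carbon. Within the data shown here, no measured step covers this change, so any shift in this assay is uncertain; a small step toward less compound, or none beyond the scatter, is expected. On that basis compound 4 is estimated at 100 mg/kg, between 50 mg/kg and 250 mg/kg. The expected step of a number no higher from compound 1 to compound 4 (the limit leaves the size open) is modest.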

Compound 4, dose for half-maximal effect: 136 mg/kg
For compound 4 the middle estimate is 1.4-fold (0.13 log units) below the measured one; the measured number falls inside the stated range.
By their numbers in this assay, from the lowest: compounds 2, 3 and 4 (each within the scatter of the next).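

In this assay, within the data shown here, compound 1 stands only as the limit > 100 mg/kg and no step to compound 4 can be read from it. The compounds shown leave open how far the change from isopropyl to ethyl moves the dose needed.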